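The source may report more compounds than this note shows. Statements on the series, on what has been measured and on what is new or still open speak of the compounds shown alone.

Measured compounds in an assay on HEK293 cells with D(4) dopamine receptor (Homo sapiens) as the target, read by FLIPR; a higher number here means a larger maximal response, a lower number a smaller maximal response: compound 1 `Fc1cccnc1N1CCN(Cc2nc3ccccc3[nH]2)CC1` gives 27%; compound 2 `CSc1ccccc1N1CCN(Cc2nc3ccccc3[nH]2)CC1` gives 42%.

Compound 2 stands highest of the two, with compound 1 nearest at a number 15 percentage points higher from compound 1 to compound 2 (beyond the scatter).

Compound 3 `c1cnc(N2CCN(Cc3nc4ccccc4[nH]3)CC2)nc1` is not yet measured. It differs from compound 2 as follows: pyrimidin-2-yl in place of 2-(methylsulfanyl)phenyl on an amine nitrogen in a ring.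

Among the compounds with values here, the only step that bears on this is the one at the same position, a number 15 percentage points higher from compound 1 to compound 2 (beyond the scatter), where an aromatic ring with one nitrogen was replaced by a carbon-only ring bearing a methylsulfanyl group. Compound 3 returns to a nitrogen-containing ring, now with two nitrogens, and so resembles compound 1 more than compound 2 in this respect. A downward step is therefore expected in this assay, roughly reversing the earlier one; the expected step is a number 14 percentage points lower from compound 2 to compound 3 (beyond the scatter).

Compound 3 is estimated at 28% in this assay, with a range from 12% to 45%.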

Compound 3, largest response reached (reported as efficacy), in percent of the reference or control that the assay uses: 49%
Estimate against measurement, compound 3: 21 percentage points below; measured number above the stated range.
By their numbers in this assay, from the lowest: compound 1; then compounds 2 and 3 (each within the scatter of the next).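

In this assay the step to pyrimidin-2-yl, a number 7 percentage points higher from compound 2 to compound 3 (within the scatter), leaves it level with 2-(methylsulfanyl)phenyl, so a nitrogen-containing ring at this position need not give the low response of compound 1. Against 3-fluoropyridin-2-yl, the same group gives a number 22 percentage points higher from compound 1 to compound 3 (beyond the scatter), which separates two nitrogen-containing rings at this position. Nothing available accounts for this difference.

Open, as far as these compounds go, is whether the fluorine of compound 1 goes with its lower response, which pyridin-2-yl without fluorine would test. Also open, from the compounds shown here alone, is how an unsubstituted phenyl group would compare here.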